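Aryl swap on the piperazine of an oxindole series

The source may report more compounds than this note shows. Statements on the series, on what has been measured and on what is new or still open speak of the compounds shown alone.

Among the compounds with values here, compound 1 `CCC1(CCCCN2CCN(c3ccc(F)cc3)CC2)C(=O)Nc2ccccc21` is the one member of this set with a number behind it. In a functional assay on the whole organism (strain NMRI) with Mus musculus as the target, with a stated time of 5 min (a lower number here means that less compound is needed, a higher number that more compound is needed for the effect), compound 1 reaches a limit of the assay, < 1 mg/kg. Compound 2 `CCC1(CCCCN2CCN(c3ccccc3OC)CC2)C(=O)Nc2ccccc21` bears a 2-methoxyphenyl on an amine nitrogen in a ring, yet for compound 2 this assay returned "not determined" (no result reported), so compound 2 stands nowhere on the numbers shown; the only mark beside it is the limit of < 1 mg/kg in this assay, at which 1 of the 2 values shown sits. Compound 3 `CCC1(CCCCN2CCN(c3cccc(Cl)c3)CC2)C(=O)Nc2ccccc21` differs from compound 2 as follows: 3-chlorophenyl in place of 2-methoxyphenyl on an amine nitrogen in a ring. Within the data shown here, with no measured step to lean on, a shift in this assay no greater than the usual scatter, in either direction, is expected. Compound 3 is estimated at 1 mg/kg, with a range from 0.3 mg/kg to 3 mg/kg.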

Compound 3, minimum effective dose: > 10 mg/kg
Compound 3: only a limit was reported; the forecaster's own chance of this, stated with the estimate: 50%; middle value at least 10-fold (1.00 log units) from the limit.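

The amine nitrogen in a ring is sensitive to which aryl group it carries, a point that compound 1 and compound 2 alone could not show. In this assay compound 3 gives > 10 mg/kg, which is a limit of the assay. Replacing 4-fluorophenyl with 3-chlorophenyl gives an at least 10-fold higher number from compound 1 to compound 3 (1.00 log units; beyond the scatter), so this single change on the shared core separates the two compounds beyond the scatter.

Any step involving compound 2 cannot be read, so the 2-methoxyphenyl group remains unplaced. The compounds shown also leave open what a plain phenyl group on that nitrogen would give, and whether the halogen's identity or its place on the ring drives the step.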